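The source may report more compounds than this note shows. Statements on the series, on what has been measured and on what is new or still open speak of the compounds shown alone.

Measured so far in a functional assay on the whole organism (Tail, strain ICR) with Mus musculus as the target, in the tail flick test, with a stated time of 90 min, at a dose of 25 umol/kg by the oral route; a higher number here means a stronger effect of the compound at the dose given, a lower number a weaker effect:

- compound 1, `N=C(N)NCCC[C@H](NC(=O)CN(c1nc(Cl)nc2[nH]cnc12)C1CC1)C(=O)O`: 27.6%
- compound 2, `O=C(CN(c1nc(Cl)nc2[nH]cnc12)C1CC1)N[C@@H](CO)C(=O)O`: 43.9%

Within the data shown here, compound 2 gives the highest of the two numbers in this assay; the only other value, that of compound 1, lies below it, and the step of a number 16.3 percentage points higher from compound 1 to compound 2 (beyond the scatter) is beyond the scatter.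

The next compound, compound 3, `NC(=O)C[C@H](NC(=O)CN(c1nc(Cl)nc2[nH]cnc12)C1CC1)C(=O)O`, is not yet measured. Its change against compound 2 is carbamoyl in place of hydroxy on a saturated chain carbon, two bonds along the chain from an amide-type nitrogen and a carbonyl carbon. Among the measured compounds shown here, the one measured step that bears on this position is a number 16.3 percentage points higher from compound 1 to compound 2 (beyond the scatter), in which a group of six heavy atoms gave way to hydroxy at the same saturated chain carbon. The present change goes the other way in size, from one heavy atom to three, but the entering carbamoyl is far smaller than the group that left in that earlier step, so a return toward the value of compound 1 is not expected in full. A small fall, or no step beyond the scatter, is the expectation in this assay.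

For compound 3 the estimate in this assay is 38%, with a range from 22% to 54%; this is expected to mean a step of a number 5.9 percentage points lower from compound 2 to compound 3 (within the scatter).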

Compound 3, a percentage reported as activity, at one dose (the size of the read-out at that dose, not a potency): 20.1%
Compound 3: the middle estimate sits 17.9 percentage points above what was measured; measured number below the stated range.
By their numbers in this assay, from the lowest: compounds 3 and 1 (each within the scatter of the next); then compound 2.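

In this assay, carbamoyl in place of hydroxy gives a number 23.8 percentage points lower from compound 2 to compound 3 (beyond the scatter), so the level reached with hydroxy at this saturated chain carbon is not kept with carbamoyl. The replacement of the group of 6 heavy atoms by carbamoyl gives a number 7.5 percentage points lower from compound 1 to compound 3 (within the scatter), so among the three compounds only compound 2 stands apart, and two side chains of different size and make-up share one level. No measurement at hand gives a reason for this result.

The compounds shown leave open whether the level of compound 2 is tied to the hydroxy group itself or to the short chain that carries it, which a methoxy group or a longer chain ending in hydroxy at the same saturated chain carbon would help to separate. Also open, as far as these compounds go, is where a carboxylic acid or an amine at this carbon would fall, and whether this order holds at other doses and times in the tail flick test.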